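The source may hold more compounds than are shown below. What is called first, only, known or untested is meant among the compounds shown, and "the series" means these compounds.

Of the compounds shown here, three built on a shared core have been measured in a functional assay on Jurkat cells (Homo sapiens) for antiproliferative activity, read by MTT assay, with a stated time of 72 h; a lower number here means a stronger inhibitor, a higher number a weaker inhibitor. Compound 1 `CNc1nc(-c2cc(OC)c(OC)c(OC)c2)c(-c2ccc(C)cc2)s1` gives 19 nM, and compound 2 `CNc1nc(-c2cc(OC)c(OC)c(OC)c2)c(-c2ccc(OC)cc2)s1` gives 34.3 nM. Compound 3 `COc1cc(-c2nc(N(C)C)sc2-c2ccc(C)cc2)cc(OC)c1OC` gives 6660 nM, the highest number of the three, which makes it the weakest inhibitor of this small set. What separates it from the others is a 350-fold higher number from compound 1 to compound 3 (2.54 log units; beyond the scatter), a large step that comes with methyl in place of hydrogen on a nitrogen on an aromatic ring.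

Compound 4 `COc1ccc(-c2sc(N(C)C)nc2-c2cc(OC)c(OC)c(OC)c2)cc1` has not yet been measured. It keeps that nitrogen as it is in compound 3 and changes elsewhere: methoxy in place of methyl on an aromatic carbon. In words, this is methoxy in place of methyl on an aromatic carbon.

The same swap has been measured once, as a 1.8-fold higher number from compound 1 to compound 2 (0.26 log units; within the scatter). That step lies within the scatter, so it shows no real change. Going by these compounds, it is a single pair, though, and both of its members carry a hydrogen on the nitrogen, so whether it holds for compound 3 is untested. No step beyond the scatter is therefore expected, and the estimated change is a 1.2-fold higher number from compound 3 to compound 4 (0.08 log units; within the scatter). For compound 4 the expected value is 8000 nM, with an estimated range from 3000 nM to 25000 nM.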

Compound 4, half-maximal inhibitory concentration: 7600 nM
For compound 4 the middle estimate is 1.1-fold (0.02 log units) above the measured one; the measured number falls inside the stated range.
By their numbers in this assay, from the lowest: compounds 1 and 2 (each within the scatter of the next); then compounds 3 and 4 (each within the scatter of the next).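

With a second methyl on the nitrogen, the change from 4-methylphenyl to 4-methoxyphenyl in this assay again makes no real difference, giving a 1.1-fold higher number from compound 3 to compound 4 (0.06 log units; within the scatter) and so extending a finding that rested on a single pair to a second core. The size of this swap therefore does not depend on whether the nitrogen carries a hydrogen or a methyl in these four compounds: the same change on two cores in this assay, a 1.8-fold higher number (0.26 log units; within the scatter) from compound 1 to compound 2 and a 1.1-fold higher number (0.06 log units; within the scatter) from compound 3 to compound 4, 1.6-fold (0.20 log units) apart, within the scatter of two such steps. The large jump that comes with methyl in place of hydrogen on the nitrogen also appears again with the methoxy group in place, as a 220-fold higher number from compound 2 to compound 4 (2.35 log units; beyond the scatter), so it no longer rests on one pair either: the same change on two cores in this assay, a 350-fold higher number (2.54 log units; beyond the scatter) from compound 1 to compound 3 and a 220-fold higher number (2.35 log units; beyond the scatter) from compound 2 to compound 4, 1.6-fold (0.20 log units) apart, within the scatter of two such steps.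

The compounds shown carry only hydrogen or methyl on that nitrogen, so it stays open whether an ethyl group or an acetyl group there would give numbers like those of compound 1 or like those of compound 3. At the position para to a large group only methyl and methoxy appear, and a chlorine or a hydroxyl group there could behave differently, while nothing here tells why the extra methyl on the nitrogen has so large an effect.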